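Methyl Step Carried From Lactone Pair to Ester Pair

The source may hold more compounds than are shown below. What is called first, only, known or untested is meant among the compounds shown, and "the series" means these compounds.

Compound 1 `O=C1C=CC[C@H](c2cccc3ccccc23)O1` gives 800 nM in a functional assay on PC-3 cells (Homo sapiens) for cytotoxicity, read by MTT assay, with a stated time of 48 h; on this read-out higher numbers stand for weaker inhibition and lower numbers for stronger inhibition. Compound 2 `Cc1ccc([C@H]2CC=CC(=O)O2)c2ccccc12` gives 50 nM in this assay. The change between them is methyl in place of hydrogen on an aromatic carbon and the step is a 16-fold lower number from compound 1 to compound 2 (1.20 log units; beyond the scatter). Compound 3 `C=CC[C@@H](OC(=O)C=C)c1cccc2ccccc12` gives 22900 nM in this assay, the highest number of the three measured; how its core differs from that of compound 1 is not broken down here. Compound 4 `C=CC[C@@H](OC(=O)C=C)c1ccc(C)c2ccccc12` carries the same kind of change, (methyl in place of hydrogen on an aromatic carbon); the surroundings differ in that the methyl stands para to a group of 9 heavy atoms rather than para to a group of 7 heavy atoms. Compound 4 is expected to give a step of a 7.6-fold lower number from compound 3 to compound 4 (0.88 log units; beyond the scatter), smaller than a 16-fold lower number from compound 1 to compound 2 (1.20 log units; beyond the scatter) because compound 3 begins at 22900 nM on a core not compared against that of compound 1. Compound 4 is estimated at 3000 nM, between 800 nM and 15000 nM.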

Compound 4, half-maximal inhibitory concentration: 45000 nM
Compound 4: the middle estimate sits 15-fold (1.18 log units) below what was measured; measured number above the stated range.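

In this assay, the new step is a 2.0-fold higher number from compound 3 to compound 4 (0.29 log units; within the scatter), so compound 3 and compound 4 cannot be told apart on this core. Methyl in place of hydrogen on an aromatic carbon therefore does not carry its large effect from the core of compound 1 to the core of compound 3, and the two steps differ: the same change on two cores in this assay, a 16-fold lower number (1.20 log units; beyond the scatter) from compound 1 to compound 2 and a 2.0-fold higher number (0.29 log units; within the scatter) from compound 3 to compound 4, 31-fold (1.50 log units) apart, beyond the scatter of two such steps. This rests on one pair per core, so it shows that the step depends on the core in these two pairs but not what in the cores accounts for the difference.

Open, going by these compounds, is whether an ethyl group or an amine in place of the methyl would separate either pair. Also open, on these data alone, is whether the two cores would respond alike to such groups.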